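The source may hold more compounds than are shown below. What is called first, only, known or untested is meant among the compounds shown, and "the series" means these compounds.

Compound 1, with the structure `Cc1nc(C(=O)N[C@H]2CC[C@H](C)CC2)c(C)c(-c2ccc(Cl)cc2)c1[C@H](OC(C)(C)C)C(=O)O`, was tested in an ADME assay on microsomes from liver (Homo sapiens) for metabolic stability (on this read-out lower numbers stand for a shorter-lived compound and higher numbers for a longer-lived compound), and gives 3.07 h. Compound 2, with the structure `Cc1cccc(NC(=O)c2nc(C)c([C@H](OC(C)(C)C)C(=O)O)c(-c3ccc(Cl)cc3)c2C)c1`, differs from compound 1 only in the group on the amide-type nitrogen. In this assay compound 2 reaches a limit of the assay, > 5 h, so that only a range and no exact number is known for it, as shown by the limit of > 5 h in this assay, at which 1 of the 2 values shown sits. Going by these compounds, the step of an at least 1.6-fold higher number from compound 1 to compound 2 (0.21 log units; that floor lies within the scatter) therefore rests on a floor that lies within the scatter, and its true size remains open.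

Compound 3, with the structure `Cc1ccc2[nH]c(-c3nc(C)c([C@H](OC(C)(C)C)C(=O)O)c(-c4ccc(Cl)cc4)c3C)nc2c1`, carries a different change: 5-methyl-1H-benzimidazol-2-yl in place of (3-methylphenyl)carbamoyl on an aromatic carbon, in words 5-methyl-1H-benzimidazol-2-yl in place of (3-methylphenyl)carbamoyl on an aromatic carbon. Among the measured compounds shown here, the only measured step, the one from compound 1 to compound 2, concerns the substituent on the amide-type nitrogen and not the replacement of the whole carbamoyl group, so it gives no direct guide. The expected step is a number no higher from compound 2 to compound 3 (the limit leaves the size open), that is, none beyond the scatter. Compound 3 is estimated to reach 5 h in this assay, with a range from 2 h to 12 h.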

Compound 3, half-life: 2.77 h
For compound 3 the middle estimate is 1.8-fold (0.26 log units) above the measured one, and the stated range covers the measured number.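

In this assay, this position proves open to more than a change on the amide-type nitrogen: the whole carbamoyl group can give way to 5-methyl-1H-benzimidazol-2-yl, which brings in a five-membered aromatic ring with 2 hetero atoms, and the outcome is a 1.1-fold lower number from compound 1 to compound 3 (0.04 log units; within the scatter). Compound 2 carries only a limit of the assay, > 5 h. Against that compound the same replacement reads as an at least 1.8-fold lower number from compound 2 to compound 3 (0.25 log units; that floor lies within the scatter), and the true size of this step stays open because one end of it is not an exact number: the limit of > 5 h in this assay, at which 1 of the 3 values shown sits.

The compounds shown leave open whether the methyl group on the 5-methyl-1H-benzimidazol-2-yl plays any part in the half-life, and whether a fluorine atom or a methoxy group in its place would read the same. Going by these compounds, it also remains open whether an imidazol-2-yl group, without the six-membered carbon ring, would hold the half-life at this position, and how the tert-butoxy group elsewhere on the shared core would respond to a change of its own.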